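Turning the amide around on the shared core

The source may hold more compounds than are shown below. What is called first, only, known or untested is meant among the compounds shown, and "the series" means these compounds.

In a physicochemical assay for lipophilicity, at pH 7.4 (a higher number here means a more lipophilic compound, a lower number a more polar compound), compound 1 `Cc1cc(C(=O)Nc2ccc(F)cc2)nn1Cc1cc(Cl)ccc1OCc1ccccc1` gives 3. Compound 2 `Cc1cc(C(=O)NCc2ccccc2)nn1Cc1cc(Cl)ccc1OCc1ccccc1` reaches only the limit of this assay, > 3.7. Compound 3 `Cc1cc(C(=O)NCc2ccncc2)nn1Cc1cc(Cl)ccc1OCc1ccccc1` likewise returns only a limit, > 3.7. The steps from the numbered value are readable, a number at least 0.70 log units higher from compound 1 to compound 2 (beyond the scatter) and a number at least 0.70 log units higher from compound 1 to compound 3 (beyond the scatter), whereas a step that the two limits leave unreadable from compound 2 to compound 3. Compound 3 therefore stands at the limit of > 3.7 in this assay, at which 2 of the 3 values shown sit, without a number of its own. Compound 4 `Cc1cc(NC(=O)c2ccccc2)nn1Cc1cc(Cl)ccc1OCc1ccccc1` differs from compound 3 by benzamido in place of ((pyridin-4-yl)methyl)carbamoyl on an aromatic carbon. Within the data shown here, no measured step covers this change; the steps from compound 1 fix only that compound 2 and compound 3 lie beyond it. Compound 4 is expected to sit near the limit again, estimated at 3.9 within 3.4 to 4.4. Compound 4 is thus expected to show a step that the limit leaves unreadable from compound 3 to compound 4.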

Compound 4, distribution coefficient: > 3.7
Compound 4: no number, only a limit; the forecaster's own chance of this, stated with the estimate: 60%; the middle value is on the limit's open side.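

In this assay, the turned amide, benzamido in place of (4-fluorophenyl)carbamoyl on the aromatic carbon, gives a number at least 0.70 log units higher from compound 1 to compound 4 (beyond the scatter). Compound 4 returns a limit and no number, so it joins compound 2 and compound 3: the limit of > 3.7 in this assay, at which 3 of the 4 values shown sit. The steps among these three cannot be read, and so turning the amide has no size here against either chain-linked amide.

As far as these compounds go, how far any of the three lies past the limit stays open. Also open, from the compounds shown here alone, is whether an amine or a carboxylic acid on the benzamido group would return a number in this assay.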